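Dinitro-trifluoromethylphenyl ether oximes: chlorobenzyl substitution notes

This account rests on a few compounds, and the source may have more. Where it says the series, first, only, none or still open, it means among the compounds named here.

Measured so far in a functional assay on HepG2 cells (Homo sapiens) for antiproliferative activity, read by MTT assay, with a stated time of 48 h; on this read-out lower numbers stand for stronger inhibition and higher numbers for weaker inhibition:
- compound 1, `O=[N+]([O-])c1cc(C(F)(F)F)cc([N+](=O)[O-])c1Oc1ccccc1/C=N/OCc1ccccc1Cl`: 1170 nM
- compound 2, `O=[N+]([O-])c1cc(C(F)(F)F)cc([N+](=O)[O-])c1Oc1ccccc1/C=N/OCc1ccc(Cl)cc1Cl`: 1020 nM
- compound 3, `O=[N+]([O-])c1cc(C(F)(F)F)cc([N+](=O)[O-])c1Oc1ccc(Cl)cc1/C=N\OCc1ccccc1Cl`: 1510 nM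

Compounds 1 and 2 share a core and differ by chloro in place of hydrogen on an aromatic carbon. That change gave a 1.1-fold lower number from compound 1 to compound 2 (0.06 log units; within the scatter), so the two values sit together within the usual scatter and no order between them is claimed.

Compound 3 carries a second core; how its core differs from that of compound 1 is not broken down here. Its number in this assay lies nearest to that of compound 1 and furthest from that of compound 2, but both gaps fall within the scatter.

Compound 4, `O=[N+]([O-])c1cc(C(F)(F)F)cc([N+](=O)[O-])c1Oc1ccc(Cl)cc1/C=N\OCc1ccc(Cl)cc1Cl`, is not yet measured. From compound 3 it differs by chloro in place of hydrogen on an aromatic carbon, which is the same change as that from compound 1 to compound 2. Because the earlier step was a 1.1-fold lower number from compound 1 to compound 2 (0.06 log units; within the scatter), the step from compound 3 to compound 4 is expected to be similarly small, a 1.1-fold lower number from compound 3 to compound 4 (0.05 log units; within the scatter). Among the measured compounds shown here, compound 4 is therefore estimated at 1350 nM in this assay, with a plausible range from 700 nM to 2600 nM, resting on the single comparable step alone.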

Compound 4, half-maximal inhibitory concentration: 1280 nM
The estimate for compound 4 lay 1.1-fold (0.02 log units) above the measured number; measured number inside the range.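

On the core of compound 3, chloro in place of hydrogen on an aromatic carbon, which turns 2-chlorobenzyl into 2,4-dichlorobenzyl, gave a 1.2-fold lower number from compound 3 to compound 4 (0.07 log units; within the scatter) in this assay. Set beside the earlier step, the change carries from one core to the other with no difference that can be told apart: the same change on two cores in this assay, a 1.1-fold lower number (0.06 log units; within the scatter) from compound 1 to compound 2 and a 1.2-fold lower number (0.07 log units; within the scatter) from compound 3 to compound 4, 1.0-fold (0.01 log units) apart, within the scatter of two such steps. This shows that the change stays within the scatter on both cores, but it does not show a real contribution from the added chloro, as agreement between two steps this small is agreement between two near-null results, and two cores give no grounds for predicting the step on a third.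

The compounds shown leave open whether another group at the same place, such as fluoro, methoxy or an amine, would behave as chloro does on these two cores. Also open, from the compounds shown here alone, is whether replacing 2-chlorobenzyl with a longer chain would move the number beyond the scatter on either core.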